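The source may report more compounds than this note shows. Statements on the series, on what has been measured and on what is new or still open speak of the compounds shown alone.

Compound 1 `COc1cc(F)ccc1-c1ccnc2[nH]c(C3CCN(CC(=O)N(C)C)CC3)cc12` in an ADME assay on microsomes from liver (Homo sapiens) for metabolic stability (on this read-out lower numbers stand for slow clearance and higher numbers for fast clearance), gives 14 uL/min.
Compound 2 `CC(C)n1cc(-c2ccnc3[nH]c(C4CCN(CC(=O)N(C)C)CC4)cc23)cnc1=O` gives 24 uL/min.
Compound 3 `CC(C)n1cc(-c2ccnc3[nH]c(C4CCN(CC(=O)N(C)C)CC4)cc23)ccc1=O` gives only a limit of the assay, < 3 uL/min.

Among the numbers shown, compound 1 stands lowest, with compound 2 nearest, a 1.7-fold higher number from compound 1 to compound 2 (0.23 log units; within the scatter). For compound 3 the reading is a limit, (the limit of < 3 uL/min in this assay, at which 1 of the 3 values shown sits). Compound 4 `COc1cc(F)ccc1-c1ccnc2[nH]c(C3CCN(C(C)=O)CC3)cc12` differs from compound 1 elsewhere: acetyl in place of (dimethylcarbamoyl)methyl on an amine nitrogen in a ring. Going by the values given here, every measured step instead exchanges the group on an aromatic carbon of the shared core, so none of them bears on a change at the amine nitrogen in the ring, and for compound 4 no step in this assay beyond the scatter is expected. Compound 4 is therefore estimated at 14 uL/min, within 6 uL/min to 30 uL/min, a step of no change at the digits printed from compound 1 to compound 4 (within the scatter).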

Compound 4, intrinsic clearance in a liver preparation (reported as CLH), per the amount of preparation that the assay uses: < 3 uL/min
Compound 4: no number, only a limit (the forecaster's own chance of this, stated with the estimate: 5%); at least 4.6-fold (0.66 log units) between middle value and limit.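

In this assay the amine nitrogen in the ring proves to be a place that counts, which the exchanges on an aromatic carbon could not show: acetyl in place of (dimethylcarbamoyl)methyl gives an at least 4.6-fold lower number from compound 1 to compound 4 (0.66 log units; beyond the scatter). Compound 1 thus has two separate places where a single exchange gives a step beyond the scatter. Compound 4 reads only as a limit, so the full size of its step stays unknown: the limit of < 3 uL/min in this assay, at which 2 of the 4 values shown sit.

On these data alone, whether a simple amine or a longer chain ending in a carboxylic acid on that nitrogen would read the same stays open. So does whether acetyl would act alike with the other groups on the aromatic carbon.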